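This account rests on a few compounds, and the source may have more. Where it says the series, first, only, none or still open, it means among the compounds named here.

Going by the values given here, compound 2 `CC(=O)Nc1cc(C)n(Cc2cc(Cl)ccc2OCc2ccccc2)n1` is the weaker of the two measured members. Among the compounds with values here, in an assay on CHO-K1 cells for displacement of a labelled ligand from prostaglandin E2 receptor EP1 subtype (Homo sapiens) (a lower number here means a stronger inhibitor, a higher number a weaker inhibitor), compound 2 gives 316 nM, the highest of the two numbers so far; the nearest is compound 1 `Cc1cc(C(=O)NCc2ccccc2)nn1Cc1cc(Cl)ccc1OCc1ccccc1`, which gives 39.8 nM. Within the data shown here, the single measured step, a 7.9-fold higher number from compound 1 to compound 2 (0.90 log units; beyond the scatter), is acetamido in place of benzylcarbamoyl on an aromatic carbon. Compound 3 `Cc1cc(NC(=O)CC(C)(C)C)nn1Cc1cc(Cl)ccc1OCc1ccccc1` has not been measured; it differs from compound 2 by tert-butyl in place of hydrogen on a saturated chain carbon bound to a carbonyl carbon. Among the measured compounds shown here, only the step from compound 1 to compound 2 bears on this change, and loosely: a benzylcarbamoyl group goes with a lower number than acetamido, but that step also reverses the amide and so does not isolate the chain itself. A modest decrease in this assay is therefore expected for compound 3, a 2.9-fold lower number from compound 2 to compound 3 (0.46 log units; beyond the scatter), with wide uncertainty. Compound 3 is estimated at 110 nM, in the range 35 nM to 350 nM.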

Compound 3, half-maximal inhibitory concentration: 10 nM
The estimate for compound 3 lay 11-fold (1.04 log units) above the measured number, outside the stated range (below it).
By their numbers in this assay, from the lowest: compound 3; then compound 1; then compound 2.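

In this assay, going by these compounds alone, the step of a 32-fold lower number from compound 2 to compound 3 (1.50 log units; beyond the scatter) comes from tert-butyl in place of hydrogen on a saturated chain carbon bound to a carbonyl carbon, so this chain carbon tolerates added bulk and is the most responsive place so far. The step of a 4.0-fold lower number from compound 1 to compound 3 (0.60 log units; beyond the scatter) for (neopentylcarbonyl)amino in place of benzylcarbamoyl on an aromatic carbon shows that the acetamido series is not inherently inferior, and compound 3 is now the strongest of the three, with both of its steps beyond the scatter. Nothing at hand bears on the cause of this gain.

A single neopentyl group cannot separate the effect of chain length from that of branching, which a straight butyl chain or a cyclohexyl ring at this place would address. From the compounds shown here alone, how far the trend extends also remains open, including whether a chain carrying an amine or a carboxylic acid is accepted here.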